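The source may report more compounds than this note shows. Statements on the series, on what has been measured and on what is new or still open speak of the compounds shown alone.

In a functional assay on HL-60 cells (Homo sapiens) for inhibition, read by CCK-8 assay, with a stated time of 48 h, tested at 20 uM (on this read-out higher numbers stand for more inhibition of growth at the one concentration tested and lower numbers for less inhibition of growth), three compounds that share one core have been measured: compound 1 (`COc1ccc(Cc2nnc(NC(=O)/C(C#N)=C/c3ccccc3OS(=O)(=O)c3ccc([N+](=O)[O-])cc3)s2)cc1`) gives 51%, compound 2 (`COc1ccc(Cc2nnc(NC(=O)/C(C#N)=C/c3ccccc3OS(=O)(=O)c3ccccc3[N+](=O)[O-])s2)cc1`) gives 25%, and compound 3 (`COc1ccc(Cc2nnc(NC(=O)/C(C#N)=C/c3ccccc3OS(=O)(=O)c3ccc(Cl)cc3)s2)cc1`) gives 20%. Compound 3 therefore stands together with compound 2 well short of compound 1. The gap between that pair is a number 5 percentage points lower from compound 2 to compound 3 (within the scatter), while the distance to the third member is a number 31 percentage points lower from compound 1 to compound 3 (beyond the scatter).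

Compound 4 (`N#C/C(=C\c1ccccc1OS(=O)(=O)c1ccc(Cl)cc1)C(=O)Nc1nnc(Cc2cccc3ccccc23)s1`) keeps the aryl group on the sulfonyl sulfur of compound 3 and differs at the other end of the molecule: naphthalen-1-yl in place of 4-methoxyphenyl on a saturated chain carbon bound to an aromatic carbon. In words, naphthalen-1-yl stands in place of 4-methoxyphenyl on a saturated chain carbon bound to an aromatic carbon.

Among the compounds with values here, no measured step touches this place. The steps at hand, a number 26 percentage points lower from compound 1 to compound 2 (beyond the scatter) and a number 31 percentage points lower from compound 1 to compound 3 (beyond the scatter), both arise on the sulfonyl side. They show that the read-out can move by a modest to large amount in this series, but they give no direction for the present change. With nothing to favour a real shift, the estimated step is a number 8 percentage points higher from compound 3 to compound 4 (within the scatter), so none beyond the scatter is expected in this assay, though the uncertainty is wide. For compound 4 the expected value is 28%, within a range from 10% to 50%.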

Compound 4, percent growth inhibition at one concentration: 15%
The estimate for compound 4 lay 13 percentage points above the measured number; measured number inside the range.
By their numbers in this assay, from the lowest: compounds 4, 3 and 2 (each within the scatter of the next); then compound 1.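

Replacing 4-methoxyphenyl with naphthalen-1-yl on a saturated chain carbon bound to an aromatic carbon gives the first step seen at this end of the molecule, a number 5 percentage points lower from compound 3 to compound 4 (within the scatter) in this assay. The read-out therefore shows no real change, although the entering group has a second six-membered aromatic ring of carbon only and no hydrogen-bond acceptor, while the leaving group has one. This swap thus stands apart from the sulfonyl-side change a number 31 percentage points lower from compound 1 to compound 3 (beyond the scatter), at least with the 4-chlorophenyl group on the sulfonyl sulfur, and no available evidence offers an explanation for the outcome.

On these data alone, it remains open whether the same swap would also leave the read-out unchanged with the 4-nitrophenyl group of compound 1, which gives 51%. Also open, as far as these compounds go, is how a carboxylic acid or an amine on the aromatic ring at this end, or a longer chain in place of the single saturated carbon, would read in this assay.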